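Oral Exposure in Mice: From Compound 2 to Compound 3

The source may report more compounds than this note shows. Statements on the series, on what has been measured and on what is new or still open speak of the compounds shown alone.

Compound 1 `CC(C)c1ccc(-c2nc(CN3CCN(c4ccnc5cc(Cl)ccc45)CC3)no2)cc1`: 5330 ng.h/mL
Compound 2 `CC(C)c1ccc(-c2nc(CN3CCN(c4ccnc5cc(-c6cccnc6)ccc45)CC3)no2)cc1`: 11900 ng.h/mL

Both were measured in an ADME assay on the whole organism (Mus musculus, strain BALB/c) for pharmacokinetics, at a dose of 30 mg/kg by the oral route; on this read-out higher numbers stand for higher exposure at the dose given and lower numbers for lower exposure. Compound 2 holds the higher of the two numbers, separated from compound 1 by the step of a 2.2-fold higher number from compound 1 to compound 2 (0.35 log units; beyond the scatter). Compound 3 `Cc1cccc(-c2nc(CN3CCN(c4ccnc5cc(-c6cccnc6)ccc45)CC3)no2)c1C` differs from compound 2 in one place: 2,3-dimethylphenyl in place of 4-isopropylphenyl on an aromatic carbon. For the measured compounds named here, the only measured step, a 2.2-fold higher number from compound 1 to compound 2 (0.35 log units; beyond the scatter), concerns a different exchange and offers no guide to this one. Compound 3 is therefore expected to show a 1.1-fold lower number from compound 2 to compound 3 (0.03 log units; within the scatter), a change within the scatter. Compound 3 is estimated at 11000 ng.h/mL, with a range from 4000 ng.h/mL to 28000 ng.h/mL.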

Compound 3, area under the concentration-time curve: 8310 ng.h/mL
Compound 3: middle estimate off by 1.3-fold (0.12 log units), on the high side, within the range that was stated.
By their numbers in this assay, from the lowest: compounds 1, 3 and 2 (each within the scatter of the next, the first and the last beyond it).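

At this aromatic carbon of the five-membered ring, 2,3-dimethylphenyl in place of 4-isopropylphenyl gives a 1.4-fold lower number from compound 2 to compound 3 (0.16 log units; within the scatter) in this assay. The two carbon-only aryl groups therefore cannot be told apart on this read-out, even though their alkyl groups differ in shape and placement. No measurement at hand accounts for this result.

Going by these compounds, whether this tolerance extends beyond carbon-only groups remains open: a phenyl ring carrying an amine or a carboxylic acid could behave differently at this carbon. On these data alone, the effect of each methyl alone also remains unknown.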